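The compounds below may be only part of what the source reports. "The series", "measured", "known", "first", "only" and "open" are said of these compounds alone.

Measured compounds:
Compound 1, `C=C1CN/C(=N/c2ccccc2)S1`: in a functional assay on MCF7 cells (Homo sapiens) for antiproliferative activity, read by MTT assay, with a stated time of 72 h (on this read-out higher numbers stand for weaker inhibition and lower numbers for stronger inhibition), compound 1 gives > 100000 nM, which is a limit of the assay.
Compound 2, `COc1ccc(/C=C2\S/C(=N\c3ccc(F)cc3)N(C)C2=O)cc1`: in this assay compound 2 gives 66500 nM.
Compound 3, `S=C(Nc1ccccc1)N1C/C(=C/c2ccccc2)S/C1=N\c1ccccc1`: in this assay compound 3 gives > 100000 nM, which is also a limit.

Compound 2 thus stands alone as the only result in this assay that is a number; the other two results sit at the limit of > 100000 nM in this assay, at which 2 of the 3 values shown sit. Compound 4, `COc1ccc(/C=C2\S/C(=N\c3ccc(C)cc3)N(C)C2=O)cc1`, has yet to be measured in this assay. It differs from compound 2 in one place: methyl in place of fluoro on an aromatic carbon. For the measured compounds named here, no pair of measured compounds in this set differs in a single place, so there is no measured step to lean on. The exchange of one heavy atom for another of the same size at the same position is a modest change, and no shift beyond the usual scatter is expected in either direction. The expected step is accordingly a 1.1-fold lower number from compound 2 to compound 4 (0.04 log units; within the scatter). Compound 4 is estimated at 60000 nM, with a range from 20000 nM to 200000 nM, and with a real chance that the assay returns only a limit rather than a number.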

Compound 4, half-maximal inhibitory concentration: > 100000 nM
Compound 4 gave a limit, no number; the forecaster's own chance of this, stated with the estimate: 35%; at least 1.6-fold (0.22 log units) between middle value and limit.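

In this assay, for the compounds shown here, the exchange of fluoro for methyl on this aromatic carbon gives the first measured step in the set, an at least 1.5-fold higher number from compound 2 to compound 4 (0.17 log units; that floor lies within the scatter). Compound 4 gives > 100000 nM, which is a limit of the assay and not a number. Going by these compounds alone, the step from 4-fluorophenyl to 4-methylphenyl therefore has only a floor, so the pair points in one direction without settling whether the change exceeds ordinary repeat variation, and compound 2 remains the only compound with a number: the limit of > 100000 nM in this assay, at which 3 of the 4 values shown sit.

From the compounds shown here alone, the true size of the step stays open, since only its floor can be read. Also open, going by these compounds, is what a chlorine atom or an amine would do on this aromatic carbon, and whether any group here would give a lower number than fluoro does.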